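Sulfonyl to sulfanyl exchange in a growth inhibitor series

A few compounds are considered here, and "the series" means these few. Any claim that something is new, unique, unknown or untested is made for them only; others in the source may bear on it.

- compound 1 `Cc1ccc(CS/C(=C/c2ccccc2F)C(=O)c2ccc(Cl)cc2)cc1` gives 10000 nM in a functional assay on DU-145 cells (Homo sapiens) for inhibition, read by trypan blue exclusion, with a stated time of 96 h; a higher number here means a weaker inhibitor of growth, a lower number a stronger inhibitor of growth
- compound 2 `COc1ccc(S(=O)(=O)/C(=C/c2ccccc2OCc2ccccc2)C(=O)c2ccc(Cl)cc2)cc1` gives 1000 nM in this assay

Of the two measured compounds, compound 2 has the lower number, and its gap to compound 1 lies beyond the usual scatter. Compound 3 `Cc1ccc(CS/C(=C/c2ccccc2OCc2ccccc2)C(=O)c2ccc(Cl)cc2)cc1` follows from compound 2, with (4-methylbenzyl)sulfanyl in place of (4-methoxyphenyl)sulfonyl on a double-bonded chain carbon bound to a carbonyl carbon and a double-bonded chain carbon. Among the measured compounds shown here, no measured pair isolates this change, so its size remains open. Compound 1 also carries (4-methylbenzyl)sulfanyl and gives 10000 nM in this assay but differs from compound 2 elsewhere as well, so it offers only a weak guide. A moderate rise in the number is therefore expected, possibly not far beyond the scatter. The estimated change is a 3.0-fold higher number from compound 2 to compound 3 (0.48 log units; beyond the scatter) in the expected direction. For compound 3 the estimate is 3000 nM with an expected range from 800 nM to 10000 nM in this series.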

Compound 3, concentration for 50% growth inhibition: 1000 nM
Compound 3: the middle estimate sits 3.0-fold (0.48 log units) above what was measured; low and high end bracket the measured number.
By their numbers in this assay, from the lowest: compounds 2 and 3 (each within the scatter of the next); then compound 1.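

In this assay, (4-methylbenzyl)sulfanyl in place of (4-methoxyphenyl)sulfonyl on a double-bonded chain carbon bound to a carbonyl carbon and a double-bonded chain carbon gives no change at the digits printed from compound 2 to compound 3 (within the scatter), so with benzyloxy held fixed on the aromatic carbon, these two groups cannot be told apart at this position, despite their different sulfur linkage and heavy-atom counts. With (4-methylbenzyl)sulfanyl held fixed, benzyloxy in place of fluoro on an aromatic carbon gives a 10-fold lower number from compound 1 to compound 3 (1.00 log units; beyond the scatter), so among these one-place steps, only the change at the aromatic carbon moves the number beyond the scatter. No supporting measurement bears on either step.

Still open, from the compounds shown here alone, is whether the match between the two sulfur groups holds with fluoro on the aromatic carbon, as (4-methoxyphenyl)sulfonyl appears here only with benzyloxy. Also open, going by these compounds, is how the growth read-out would respond to an amine or a carboxylic acid on the double-bonded chain carbon, or to a longer alkoxy chain in place of benzyloxy on the aromatic carbon.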